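The compounds below may be only part of what the source reports. "The series", "measured", "known", "first", "only" and "open" are said of these compounds alone.

Measured so far:
compound 1, `CCN(CC)CC(=O)N1N=C(C)CC1c1ccccc1OC(C)=O` — in a functional assay on MGC-803 cells (Homo sapiens) for cytotoxicity, read by MTT assay, with a stated time of 48 h (on this read-out higher numbers stand for weaker inhibition and lower numbers for stronger inhibition), compound 1 gives 29500 nM
compound 2, `CCC(=O)N1N=C(c2cc3ccccc3oc2=O)CC1c1ccccc1` — in this assay compound 2 gives 5300 nM

Compound 2 holds the lower of the two numbers; compound 1 sits higher, and that gap lies beyond the scatter. Compound 3, `Cc1ccc(S(=O)(=O)N2N=C(c3cc4ccccc4oc3=O)CC2c2ccccc2)cc1`, is not yet measured. It differs from compound 2 by (4-methylphenyl)sulfonyl in place of propanoyl on an amine nitrogen in a ring. Among the measured compounds shown here, no measured pair shows this exchange, so the size of the step is open. Only a small movement, not clearly beyond the scatter, is expected, and the estimated step is a 1.3-fold lower number from compound 2 to compound 3 (0.12 log units; within the scatter). For compound 3 the expected value in this assay is 4000 nM, with a range from 1200 nM to 14000 nM.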

Compound 3, half-maximal inhibitory concentration: 50200 nM
The estimate for compound 3 lay 13-fold (1.10 log units) below the measured number; the measured number lies above the stated range.
By their numbers in this assay, from the lowest: compound 2; then compounds 1 and 3 (each within the scatter of the next).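

On the amine nitrogen in the ring, this position is sensitive to the group it carries: in this assay (4-methylphenyl)sulfonyl in place of propanoyl gives a 9.5-fold higher number from compound 2 to compound 3 (0.98 log units; beyond the scatter). Of the two groups compared on this core, propanoyl goes with the stronger inhibition. No available evidence accounts for this step.

From the compounds shown here alone, whether the sulfonyl link or the 4-methylphenyl ring drives the step remains open; methanesulfonyl and benzoyl at this nitrogen would separate the two. Going by these compounds, how a longer acyl chain would behave here is also open.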